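The source may report more compounds than this note shows. Statements on the series, on what has been measured and on what is new or still open speak of the compounds shown alone.

In a functional assay on L02 cells (Homo sapiens) for inhibition (a lower number here means a stronger inhibitor, a higher number a weaker inhibitor), compound 1 `O=C(CC(CC(=O)NC1Cc2ccccc2C1)c1ccc(Cl)cc1)NCCN1CCCCC1` gives 70400 nM. Compound 2 `O=C(CC(CC(=O)NC1Cc2ccccc2C1)c1ccccc1)NCCN1CCCCC1` gives > 100000 nM, which is a limit of the assay and not a number. Compound 2 therefore sits at the limit of > 100000 nM in this assay, at which 1 of the 2 values shown sits.

The next structure is compound 3 `CCN(CC)CCNC(=O)CC(CC(=O)NC1Cc2ccccc2C1)c1ccccc1`, and the change is diethylamino in place of piperidin-1-yl on a saturated chain carbon, two bonds along the chain from an amide-type nitrogen. Diethylamino stands in place of piperidin-1-yl on a saturated chain carbon, two bonds along the chain from an amide-type nitrogen.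

Among the compounds with values here, the only measured step is an at least 1.4-fold higher number from compound 1 to compound 2 (0.15 log units; that floor lies within the scatter). It swaps chloro for hydrogen on an aromatic carbon and leaves the piperidin-1-yl group untouched, so it bears on the present change only indirectly. Within the data shown here, no measured step covers an exchange at this amine, so no shift beyond the scatter is expected in this assay, and neither direction is favoured. Compound 3 is therefore expected to stay weak, and another report of only a limit is quite possible. The expected step is a number no higher from compound 2 to compound 3 (the limit leaves the size open). For compound 3 the estimated value is 100000 nM, with an expected range from 50000 nM to 200000 nM.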

Compound 3, half-maximal inhibitory concentration: > 100000 nM
Compound 3: only a limit was reported; the forecaster's own chance of this, stated with the estimate: 60%; the middle value lies on the limit itself.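

In this assay compound 2 gives > 100000 nM, which is a limit and not a number. Within the data shown here, compound 3 gives > 100000 nM, also a limit, so no step between compound 2 and compound 3 can be read. The compounds shown leave open how diethylamino and piperidin-1-yl compare in this assay.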